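The source may report more compounds than this note shows. Statements on the series, on what has been measured and on what is new or still open speak of the compounds shown alone.

Of the compounds shown here, three sharing one core have been measured in an ADME assay on S9 fraction from liver (Rattus norvegicus) for metabolic stability, read by LC-MS, using NADPH, with a stated time of 30 min; a higher number here means that more of the compound is left, a lower number that less of the compound is left. Compound 1 `CCCCCCCCc1ccc(OCC(=O)Cn2nnc(-c3cccc(C(=O)OC)c3)n2)cc1` gives 19% in this assay. Compound 2 `CCCCCCCCc1ccc(OCC(=O)Cn2nnc(-c3cccc(S(=O)(=O)N(C)C)c3)n2)cc1` gives 9% in this assay. Compound 3 `CCCCCCCCc1ccc(OCC(=O)Cn2nnnc2-c2ccccc2Cl)cc1` gives 42% in this assay, the highest of the three numbers: the gap to compound 1 and the gap to compound 2 both lie beyond the scatter. Within the data shown here, the only single-point step among the measured compounds is a number 10 percentage points lower from compound 1 to compound 2 (within the scatter), which is the exchange of one substituent for another on the pendant aryl ring.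

Compound 4 `CCCCCCCCc1ccc(OCC(=O)Cn2nnnc2-c2ccc(C(=O)O)cc2)cc1` is not yet measured. It differs from compound 3 in one place: 4-carboxyphenyl in place of 2-chlorophenyl on an aromatic carbon. Among the measured compounds shown here, no measured step bears directly on this exchange; the step from compound 1 to compound 2 shows only that one substituent swap on that aryl ring, in that pair, stayed within the scatter, while compound 3 stands apart from both of them without a single-point comparison of its own. For compound 4 in this assay the expected step is therefore a number 2 percentage points lower from compound 3 to compound 4 (within the scatter), a change of uncertain direction that is not expected to reach clearly beyond the scatter. Compound 4 is estimated at 40% in this assay, with a range from 20% to 65%.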

Compound 4, percent of the compound remaining: 6%
Compound 4: middle estimate off by 34 percentage points, on the high side, and the stated range ends above it.
By their numbers in this assay, from the lowest: compounds 4, 2 and 1 (each within the scatter of the next, the first and the last beyond it); then compound 3.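

In this assay, putting 4-carboxyphenyl in place of 2-chlorophenyl, on the aromatic carbon between two ring nitrogen atoms, comes with a number 36 percentage points lower from compound 3 to compound 4 (beyond the scatter), so the aryl group at this place can shift the share of compound left by a large amount. Among these compounds, the only earlier single-point step, a number 10 percentage points lower from compound 1 to compound 2 (within the scatter), was a swap of one substituent on the pendant aryl ring and stayed within the scatter, so it gave no sign of a shift of this size. Nothing measured here accounts for the drop, and the result itself gives no reason for it.

The exchange alters two things at once, removing the chlorine and bringing in the carboxylic acid, so the compounds shown do not tell which of the two goes with the lower number. A plain phenyl at this place would test the part played by the chlorine, while a methyl ester or a primary amide in place of the carboxylic acid would show whether the drop depends on the acid itself.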